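The source may report more compounds than this note shows. Statements on the series, on what has been measured and on what is new or still open speak of the compounds shown alone.

Going by the values given here, compound 3 `CCN(CC)S(=O)(=O)c1ccc(S(=O)(=O)N2CCC[C@@H](C(=O)NC3CN(C(=O)OC(C)(C)C)C3)C2)cc1` stands at the low end of the three numbers measured so far: in a functional assay on MIA PaCa-2 cells (Homo sapiens) for inhibition, read by MTT assay, with a stated time of 7 days (a higher number here means a weaker inhibitor, a lower number a stronger inhibitor), compound 3 gives 200 nM, while compound 2 `CCN(CC)S(=O)(=O)c1ccc(S(=O)(=O)N2CCC[C@@H](C(=O)NC3COC3)C2)cc1` gives 2300 nM and compound 1 `CCN(CC)S(=O)(=O)c1ccc(S(=O)(=O)N2CCC[C@@H](C(=O)N(C)C(C)C)C2)cc1` gives 6200 nM. The steps of a 12-fold lower number from compound 2 to compound 3 (1.06 log units; beyond the scatter) and a 31-fold lower number from compound 1 to compound 3 (1.49 log units; beyond the scatter) both lie beyond the scatter, so compound 3 is the most potent of the three, and the shorter step a 2.7-fold lower number from compound 1 to compound 2 (0.43 log units; beyond the scatter) points the same way.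

Compound 4 `CCN(CC)S(=O)(=O)c1ccc(S(=O)(=O)N2CCC[C@@H](C(=O)NC3CN(C(=O)NC(C)(C)C)C3)C2)cc1` differs from compound 3 by (tert-butyl)amino in place of tert-butoxy on a carbonyl carbon. Among the compounds with values here, none of the measured steps touches this position; all three change the group on the other carbonyl carbon or the ring on the amide-type nitrogen, and the tert-butoxycarbonyl group was present only in compound 3. The change keeps the size and placement of the group, so only a small step, if any, is expected. The expectation for compound 4 is therefore a 1.3-fold higher number from compound 3 to compound 4 (0.10 log units; within the scatter), giving an estimated 250 nM in this assay, with a range from 80 nM to 800 nM.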

Compound 4, half-maximal inhibitory concentration: 3400 nM
Compound 4: the middle estimate sits 14-fold (1.13 log units) below what was measured, outside the stated range (above it).
By their numbers in this assay, from the lowest: compound 3; then compounds 2, 4 and 1 (each within the scatter of the next, the first and the last beyond it).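

Swapping tert-butoxy for (tert-butyl)amino on the carbonyl carbon keeps the count of heavy atoms yet gives [ a 17-fold higher number from compound 3 to compound 4 (1.23 log units; beyond the scatter) ] in this assay, so this position, untouched by the earlier steps, does not tolerate every group of that size. With the (tert-butyl)carbamoyl group in place, the azetidine-bearing side chain no longer stands apart from the others: the comparisons show [ a 1.5-fold higher number from compound 2 to compound 4 (0.17 log units; within the scatter) ] and [ a 1.8-fold lower number from compound 1 to compound 4 (0.26 log units; within the scatter) ], so the low number belongs to compound 3 and not to the azetidin-3-yl amide as such. Nothing available here accounts for the size of this step.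

The compounds shown leave open whether a (tert-butyl)(methyl)amino group, which carries no amide hydrogen, would behave like tert-butoxy or like (tert-butyl)amino. They also leave open whether a smaller ether group such as methoxy or isopropoxy on the same carbonyl carbon would keep the number of compound 3.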